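Swapping a Thiophene Head Group on a Shared Core

The compounds below may be only part of what the source reports. "The series", "measured", "known", "first", "only" and "open" are said of these compounds alone.

Measured so far:
- compound 1, `CS(=O)(=O)c1ccc(Cc2nnc3n2N=C(c2cc(Cl)sc2S(N)(=O)=O)CS3)cc1`: 22.8%
- compound 2, `CS(=O)(=O)c1ccc(Cc2nnc3n2N=C(c2cc4ccccc4c(=O)o2)CS3)cc1`: 22.4%
- compound 3, `CS(=O)(=O)c1ccc(Cc2nnc3n2N=C(c2ccc(-c4ccccc4)cc2)CS3)cc1`: 58.2%

All three share one core and differ only in the aromatic group attached to it. In a functional assay on HT-29 cells (Homo sapiens) for cytotoxicity, read by MTT assay, with a stated time of 48 h, tested at 12.5 uM (a lower number here means a weaker effect, a higher number a stronger effect of the compound at the concentration tested), compound 1 gives 22.8%. Compound 2 gives 22.4% in this assay, which sits so close to compound 1 that the two cannot be told apart. For the measured compounds named here, compound 3 gives 58.2% in this assay, a number clearly higher than that of compound 1, beyond the usual scatter, so compound 3 is the one compound here with a stronger effect.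

Compound 4, `CS(=O)(=O)c1ccc(Cc2nnc3n2N=C(c2ccc(O)c(C(N)=O)c2)CS3)cc1`, has not yet been measured. Its difference from compound 1 is this:

3-carbamoyl-4-hydroxyphenyl in place of 5-chloro-2-sulfamoylthiophen-3-yl on a carbon with a double bond to nitrogen

Going by the values given here, no measured pair in this set shows what such a change does, so the expectation rests only on the three numbers above. Two of the three groups tried give a weak effect and only one gives a strong one, so compound 4 is estimated to land near compound 1, with a step from compound 1 to compound 4 of a number 3.2 percentage points higher from compound 1 to compound 4 (within the scatter), none beyond the scatter. For compound 4 the expected value in this assay is 26%, between 12% and 42%.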

Compound 4, a percentage reported as activity, at one concentration (the size of the read-out at that concentration, not a potency): 24.8%
Compound 4: middle estimate off by 1.2 percentage points, on the high side; measured number inside the range.
By their numbers in this assay, from the lowest: compounds 2, 1 and 4 (each within the scatter of the next); then compound 3.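

In this assay, placing 3-carbamoyl-4-hydroxyphenyl in place of 5-chloro-2-sulfamoylthiophen-3-yl gives a number 2 percentage points higher from compound 1 to compound 4 (within the scatter), so at this position an exchange of a five-membered ring containing sulfur for a six-membered ring of carbon only, with the chlorine gone as well, does not separate the two compounds at this concentration. A six-membered carbon ring here is also not enough on its own to give a high read-out: compound 4 gives 24.8%, while compound 3, whose group also attaches through such a ring but carries a further phenyl ring, gives 58.2%. No measurement in hand gives a reason for these numbers.

The compounds shown leave open whether the further phenyl ring of compound 3 is what matters, since a plain phenyl group or a phenyl ring bearing a short alkyl chain at the same place would be needed to test that. They also leave open whether the carbamoyl and hydroxyl groups of compound 4 matter separately, which a phenyl ring bearing only one of them, or an amine or a carboxylic acid instead, could begin to answer.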